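Cyclopentyl for propyl on the chain of compound 3

The source may report more compounds than this note shows. Statements on the series, on what has been measured and on what is new or still open speak of the compounds shown alone.

Measured so far in a functional assay on HT-29 cells (Homo sapiens) for cytotoxicity, read by sulforhodamine B assay, with a stated time of 2 days, tested at 100 uM; on this read-out lower numbers stand for less inhibition and higher numbers for more inhibition at the one concentration tested (going by the name of the read-out):
compound 1 `O=C(Nn1c(-c2cccc([N+](=O)[O-])c2)nc2c(-c3ccc(Cl)cc3)n[nH]c2c1=O)c1ccccc1` gives 87.8%
compound 2 `CCCc1nc2c(-c3ccc(Cl)cc3)n[nH]c2c(=O)n1NC(=O)c1ccccc1` gives 91.1%
compound 3 `CCCCCc1nc2c(-c3ccc(Cl)cc3)n[nH]c2c(=O)n1NC(=O)c1ccccc1` gives 90.1%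

Compound 3 stands second highest of the three numbers; its nearest neighbour is compound 2, with a number 1 percentage points lower from compound 2 to compound 3 (within the scatter), and its furthest is compound 1, with a number 2.3 percentage points higher from compound 1 to compound 3 (within the scatter). All three values sit within the scatter of one another, so no order among them can be read.

Compound 4 `O=C(Nn1c(CCC2CCCC2)nc2c(-c3ccc(Cl)cc3)n[nH]c2c1=O)c1ccccc1` differs from compound 3 by cyclopentyl in place of propyl on a saturated chain carbon, two bonds along the chain from an aromatic carbon. The step that bears on this is the chain extension from compound 2 to compound 3, a number 1 percentage points lower from compound 2 to compound 3 (within the scatter), which lay within the scatter, as did a number 3.3 percentage points higher from compound 1 to compound 2 (within the scatter) and a number 2.3 percentage points higher from compound 1 to compound 3 (within the scatter). Compound 4 is therefore expected to show no step beyond the scatter in this assay, a number 1.1 percentage points lower from compound 3 to compound 4 (within the scatter). The estimate for compound 4 is 89%, expected between 80% and 96%.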

Compound 4, a percentage reported as inhibition, at one concentration (the size of the read-out at that concentration, not a potency): 87.3%
The estimate for compound 4 lay 1.7 percentage points above the measured number; the range from low to high includes it.
By their numbers in this assay, from the lowest: compounds 4, 1, 3 and 2 (each within the scatter of the next).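

In this assay, for the compounds shown here, the cyclopentyl ring, the first ring on a saturated chain carbon two bonds along the chain from an aromatic carbon, gives no step that can be told from the scatter (a number 2.8 percentage points lower from compound 3 to compound 4 (within the scatter)) and (a number 3.8 percentage points lower from compound 2 to compound 4 (within the scatter)). Swapping the 3-nitrophenyl for the whole 2-cyclopentylethyl does the same (a number 0.5 percentage points lower from compound 1 to compound 4 (within the scatter)). No measured evidence bears on this result.

Whether an amine or a carboxylic acid at this position would give a step beyond the scatter stays open, and so does any order among these compounds at a lower concentration.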